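Compound 3 after two limit readings

The source may report more compounds than this note shows. Statements on the series, on what has been measured and on what is new or still open speak of the compounds shown alone.

Readings in a functional assay on KB cells (Homo sapiens) for antiproliferative activity, read by MTT assay, with a stated time of 48 h (a lower number here means a stronger inhibitor, a higher number a weaker inhibitor), for the measured compounds:
- compound 1 `Cn1cc(C2=C(c3nn(CCCn4ccnc4)c4ncccc34)C(=O)NC2=O)c2ccccc21`: > 100000 nM
- compound 2 `CN(C)CCCn1nc(C2=C(c3cn(C)c4ccccc34)C(=O)NC2=O)c2cccnc21`: > 100000 nM

Compound 2 stands at > 100000 nM as a limit of the assay and not a number. Both measured compounds share the limit of > 100000 nM in this assay, at which 2 of the 2 values shown sit, and neither gives a number. Compound 3 `Cn1cc(C2=C(c3nn(CCCCn4ccnc4)c4ncccc34)C(=O)NC2=O)c2ccccc21` differs from compound 2 by (1H-imidazol-1-yl)methyl in place of dimethylamino on a saturated chain carbon, three bonds along the chain from an aromatic nitrogen in one change, (1H-imidazol-1-yl)methyl in place of dimethylamino on a saturated chain carbon, three bonds along the chain from an aromatic nitrogen. Among the measured compounds shown here, the only measured step bearing on this, a step that the two limits leave unreadable from compound 1 to compound 2, also exchanges these end groups and gives no size to carry over. In this assay the expected step of a number no higher from compound 2 to compound 3 (the limit leaves the size open) is therefore none beyond the scatter. For compound 3 the estimate is 100000 nM within an expected range of 30000 nM to 200000 nM in this assay.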

Compound 3, half-maximal inhibitory concentration: > 100000 nM
Compound 3 gave a limit, no number (the forecaster's own chance of this, stated with the estimate: 85%); the middle value lies on the limit itself.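

No step can be read among compound 1, compound 2 and compound 3, since all three give a limit and no number: the limit of > 100000 nM in this assay, at which 3 of the 3 values shown sit. From the compounds shown here alone, whether the end group or the chain changes their activity stays open.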